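A few compounds are considered here, and "the series" means these few. Any claim that something is new, unique, unknown or untested is made for them only; others in the source may bear on it.

Working notes on the series. Compound 3 `CN(C)C(=O)c1cccnc1NCCCN1CCN(c2ccccc2OCC(F)(F)F)CC1` is the tightest-binding member measured so far: in a functional assay for antagonist activity at Alpha-1A adrenergic receptor (Oryctolagus cuniculus) (on this read-out higher numbers stand for weaker binding and lower numbers for tighter binding), compound 3 gives 0.1 nM, the lowest of the three numbers, and its separation from both other compounds lies beyond the scatter. The nearest number belongs to compound 1 `COc1ccccc1N1CCN(CCCNc2ccc(C(=O)N(C)C)cn2)CC1`, which in this assay gives 25.1 nM. Compound 2 `COc1ccccc1N1CCN(CCCNc2ccccc2C(=O)c2ccccc2)CC1`, which carries a benzophenone-type amine in place of the dimethylamide pyridine, stands furthest away and in this assay gives 31.6 nM. Going by the values given here, compound 1 and compound 3 share the same amide-bearing heteroaromatic amine and the same linker and piperazine, so the gap between them arises within the aryl substitution, yet no single-point step between measured compounds is available here.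

Compound 4 `CN(C)C(=O)c1cccnc1NCCCN1CCN(c2ccccc2C(F)(F)F)CC1` is not yet measured. It differs from compound 3 in one place: trifluoromethyl in place of 2,2,2-trifluoroethoxy on an aromatic carbon. The 2,2,2-trifluoroethoxy group of compound 3 is replaced by trifluoromethyl on an aromatic carbon of a six-membered aromatic ring of carbon only, ortho to a large group, so the acceptor oxygen of the ether is lost.

Among the compounds with values here, with no measured step to anchor this change, the expected outcome is a move toward a higher number in this assay, of a size beyond the scatter, given as a 20-fold higher number from compound 3 to compound 4 (1.30 log units; beyond the scatter). Compound 4 is estimated at 2 nM, with a range from 0.3 nM to 15 nM.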

Compound 4, dissociation constant: 12.6 nM
Beside the measured number, compound 4's estimate is 6.3-fold (0.80 log units) below it; the measured number falls inside the stated range.
By their numbers in this assay, from the lowest: compound 3; then compounds 4, 1 and 2 (each within the scatter of the next, the first and the last beyond it).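

In this assay, going by these compounds alone, the exchange of 2,2,2-trifluoroethoxy for trifluoromethyl provides the first comparison between compounds that differ in one place, and it is large: a 130-fold higher number from compound 3 to compound 4 (2.10 log units; beyond the scatter). The earlier compounds shown here could not tie any part of the low number of compound 3 to a single group, whereas this step shows that the result is highly sensitive to the group on this aromatic carbon, ortho to a large group, while the rest of the structure stays the same. No measured evidence bearing on the reason for this step is available.

The exchange removes the ether oxygen and also shortens the group, so this single step cannot assign the change to either difference; ethoxy or 2,2,2-trifluoroethyl at the same place on the core of compound 3 would help to separate the oxygen from the fluorinated chain. From the compounds shown here alone, it also remains open whether a step of this size would appear with the other amine portions, such as that of compound 1 or compound 2.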